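A few compounds are considered here, and "the series" means these few. Any claim that something is new, unique, unknown or untested is made for them only; others in the source may bear on it.

Compound 1 `COc1ccc(/C=C/c2nc(NCCN(C(C)C)C(C)C)c3cc(Cl)ccc3n2)cc1OC` is tested in a functional assay on L02 cells (Homo sapiens) for cytotoxicity, read by MTT assay, with stated times of 48 h and 4 h (on this read-out lower numbers stand for stronger inhibition and higher numbers for weaker inhibition), and gives only a limit rather than a number, > 100000 nM. That limit is the limit of > 100000 nM in this assay, at which 1 of the 3 values shown sits. Compound 2 `COc1ccc(/C=C/c2nc(NCCN3CCCCC3)c3cc(Cl)ccc3n2)cc1OC` differs from compound 1 in one place: piperidin-1-yl in place of diisopropylamino on a saturated chain carbon, two bonds along the chain from a nitrogen on an aromatic ring. In this assay compound 2 gives 13900 nM, which is a step of an at least 7.1-fold lower number from compound 1 to compound 2 (0.85 log units; beyond the scatter). Compound 3 `CC(C)N(CCNc1nc(/C=C/c2ccc([N+](=O)[O-])cc2)nc2ccccc12)C(C)C` rests on a core whose difference from the core of compound 1 is not broken down here; in this assay compound 3 gives 8960 nM, and this value and that of compound 2 lie within the usual scatter of each other. Compound 4 `O=[N+]([O-])c1ccc(/C=C/c2nc(NCCN3CCCCC3)c3ccccc3n2)cc1` has not yet been measured. It differs from compound 3 by the same kind of change that separates compound 2 from compound 1, namely (piperidin-1-yl in place of diisopropylamino on a saturated chain carbon, two bonds along the chain from a nitrogen on an aromatic ring), at a place described in the same words in both cases. As far as these compounds go, because the measured step of an at least 7.1-fold lower number from compound 1 to compound 2 (0.85 log units; beyond the scatter) starts from a limit, its true size is unknown and could be larger. For compound 4 the value in this assay is expected to be about 3000 nM, between 800 nM and 10000 nM. That means an expected step of a 3.0-fold lower number from compound 3 to compound 4 (0.48 log units; beyond the scatter), a cautious reading of the earlier one.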

Compound 4, half-maximal inhibitory concentration: > 100000 nM
Compound 4 gave a limit, no number; the forecaster's own chance of this, stated with the estimate: 5%; middle value at least 33-fold (1.52 log units) from the limit.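

In this assay, putting piperidin-1-yl in place of diisopropylamino now gives an at least 11-fold higher number from compound 3 to compound 4 (1.04 log units; beyond the scatter), so neither the size nor even the direction of this change carries over from one core to the other in this series: the same change on two cores in this assay, an at least 7.1-fold lower number (0.85 log units; beyond the scatter) from compound 1 to compound 2 and an at least 11-fold higher number (1.04 log units; beyond the scatter) from compound 3 to compound 4, at least 80-fold (1.90 log units) apart, beyond the scatter of two such steps

Compound 4 gives only a limit, not a number: the limit of > 100000 nM in this assay, at which 2 of the 4 values shown sit.

As far as these compounds go, what this does not show is which feature of the two cores turns the step around; each core also supplies just one pair, and each step has a limit at one end, so the true sizes stay unknown.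

The compounds shown leave open whether the reversal goes with the chlorine and the two methoxy groups of compound 1 or with the nitro group of compound 3, since no core here carries one feature without the other. Also open, from the compounds shown here alone, is how other amines on the same chain, such as pyrrolidin-1-yl or morpholin-4-yl, or a longer chain, would behave in this assay on either core.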